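Working notes on cytotoxicity: from compound 2 to compound 4

A few compounds are considered here, and "the series" means these few. Any claim that something is new, unique, unknown or untested is made for them only; others in the source may bear on it.

Measured compounds, all in an ADME assay on HEL cells (Homo sapiens) for cytotoxicity; a higher number here means that more compound is tolerated, a lower number that less compound is tolerated:
- compound 1 `CCOc1ccc(/C=N/NC(=O)COc2cccc3ccccc23)cc1O`: 100 ug/mL
- compound 2 `C/C(=N\NC(=O)COc1cccc2ccccc12)c1cccc([N+](=O)[O-])c1`: 20 ug/mL
- compound 3 `O=C(COc1cccc2ccccc12)N/N=C/c1cccc(O)c1`: 100 ug/mL

Compound 2 stands lowest of the three numbers; compound 1 and compound 3 both lie above it by more than the scatter, and the two of them are within the scatter of each other. For the measured compounds named here, the one measured step, no change at the digits printed from compound 1 to compound 3 (within the scatter), concerns a substituent change on the aryl ring and shows no movement in this assay.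

Compound 4 `C/C(=N\NC(=O)COc1cccc2ccccc12)c1ccc(C#N)cc1Br` is not yet measured. It differs from compound 2 as follows: 2-bromo-4-cyanophenyl in place of 3-nitrophenyl on a carbon with a double bond to nitrogen. Going by the values given here, no measured step touches this kind of exchange; the step from compound 1 to compound 3 changes a different group on a different aryl ring, so it offers no direct precedent. The two other aryl variants, compound 1 and compound 3, sit higher than compound 2, which leaves open that a different aryl group moves the number up, but the data do not show what a bromine and a nitrile do here.

The estimate for compound 4 is therefore kept near compound 2, with a wide range: 30 ug/mL (15 ug/mL to 100 ug/mL), an expected step of a 1.5-fold higher number from compound 2 to compound 4 (0.18 log units; within the scatter), not clearly beyond the scatter.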

Compound 4, minimum cytotoxic concentration: 20 ug/mL
Compound 4: the middle estimate sits 1.5-fold (0.18 log units) above what was measured; low and high end bracket the measured number.
By their numbers in this assay, from the lowest: compounds 2 and 4 (each within the scatter of the next); then compounds 1 and 3 (each within the scatter of the next).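

In this assay, 2-bromo-4-cyanophenyl in place of 3-nitrophenyl on a carbon with a double bond to nitrogen gives no change at the digits printed from compound 2 to compound 4 (within the scatter). This exchange replaces the nitro-bearing aryl group with one carrying a bromine and a nitrile, and the assay does not separate the two groups at this position. No supporting measurement offers an explanation for this result.

From the compounds shown here alone, the bromine and the nitrile are read only together, so the contribution of each alone stays open, as does the effect of an amine or a carboxylic acid on this aryl ring. Also open, going by these compounds, is whether a longer chain in place of the saturated chain carbon on the same carbon would move the number in this assay.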